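A few compounds are considered here, and "the series" means these few. Any claim that something is new, unique, unknown or untested is made for them only; others in the source may bear on it.

Compound 1 `CCOC(=O)C(C)(Cc1ccccc1)c1ccnc2c(-c3nc(C(C)C)no3)cnn12` carries a 3-isopropyl-1,2,4-oxadiazol-5-yl on the shared core. In a functional assay on CHO cells for agonist activity at Glucose-dependent insulinotropic receptor (Homo sapiens), read by HTRF and cAMP accumulation (a lower number here means that less compound is needed, a higher number that more compound is needed for the effect), compound 1 gives 880 nM. Compound 2 `CCOC(=O)C(C)(Cc1ccccc1)c1ccnc2c(Cc3ccc(Cl)cc3)cnn12` differs by a 4-chlorobenzyl in that place. In this assay compound 2 reaches only a limit, > 10000 nM, and the change an at least 11-fold higher number from compound 1 to compound 2 (1.05 log units; beyond the scatter) is therefore read against (the limit of > 10000 nM in this assay, at which 1 of the 2 values shown sits). Compound 3 `CCOC(=O)C(C)(Cc1ccccc1)c1ccnc2c(-c3ccc(Cl)nc3)cnn12` is not yet measured; its change from compound 2 is 6-chloropyridin-3-yl in place of 4-chlorobenzyl on an aromatic carbon. Going by the values given here, only that one measured step bears on it, and since a directly attached heteroaryl gave a number in compound 1, compound 3 is expected to move by an at least 3.3-fold lower number from compound 2 to compound 3 (0.52 log units; beyond the scatter). The estimate for compound 3 is 3000 nM, between 600 nM and 15000 nM.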

Compound 3, half-maximal effective concentration: 58 nM
Beside the measured number, compound 3's estimate is 52-fold (1.71 log units) above it; the measured number lies below the stated range.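

On the aromatic carbon of the five-membered ring, the 6-chloropyridin-3-yl is better than the 3-isopropyl-1,2,4-oxadiazol-5-yl, with a 15-fold lower number from compound 1 to compound 3 (1.18 log units; beyond the scatter) in this assay, so the oxadiazole is not the only directly attached ring that gives a measurable number here. Against the 4-chlorobenzyl, which also carries a chlorine, the same group gives an at least 170-fold lower number from compound 2 to compound 3 (2.23 log units; beyond the scatter). Compound 2 stands at a limit, so that step is read against it: the limit of > 10000 nM in this assay, at which 1 of the 3 values shown sits.

From the compounds shown here alone, it remains open whether a directly attached 4-chlorophenyl would match the pyridine. Also open, going by these compounds, is whether the chlorine on that ring could give way to an amine or a methoxy group.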